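Bromo on the phenoxy ring of compound 2

A few compounds are considered here, and "the series" means these few. Any claim that something is new, unique, unknown or untested is made for them only; others in the source may bear on it.

- compound 1 `O=C(O)CCCCCCC(=O)Nc1ccc(C2=C(c3ccc(O)cc3)C3CC(S(=O)(=O)Oc4ccccc4C(F)(F)F)C2O3)cc1` gives 26100 nM in a functional assay on MCF7 cells (Homo sapiens) for inhibition, read by MTT assay, with a stated time of 72 h (on this read-out lower numbers stand for stronger inhibition and higher numbers for weaker inhibition), as its read-out
- compound 2 `O=C(CCCCCCC(=O)Nc1ccc(C2=C(c3ccc(O)cc3)C3CC(S(=O)(=O)Oc4ccccc4)C2O3)cc1)NO` gives 30100 nM in this assay as its read-out

Compound 2 stands level with compound 1 , the two values lying within the scatter of each other. Among the measured compounds shown here, compound 3 `O=C(CCCCCCC(=O)Nc1ccc(C2=C(c3ccc(O)cc3)C3CC(S(=O)(=O)Oc4ccc(Br)cc4)C2O3)cc1)NO` turns the phenoxysulfonyl of compound 2 into (4-bromophenoxy)sulfonyl, with bromo in place of hydrogen on an aromatic carbon as the only change. For the measured compounds named here, no measured pair isolates this change, so no step beyond the scatter is expected in this assay for it. The expected 1.2-fold lower number from compound 2 to compound 3 (0.08 log units; within the scatter) is small. For compound 3 the estimated value is 25000 nM, with an expected range from 10000 nM to 60000 nM in this series.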

Compound 3, half-maximal inhibitory concentration: 17100 nM
Compound 3: middle estimate off by 1.5-fold (0.16 log units), on the high side; low and high end bracket the measured number.
By their numbers in this assay, from the lowest: compounds 3, 1 and 2 (each within the scatter of the next).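

In this assay, among the compounds shown here, the pair compound 2 and compound 3 gives the first reading of a single change on the phenoxy ring, and it shows a 1.8-fold lower number from compound 2 to compound 3 (0.25 log units; within the scatter). Bromo in place of hydrogen on this aromatic carbon therefore leaves the read-out within the scatter. Nothing at hand bears on why this position responds as it does.

Open, from the compounds shown here alone, is whether an amine or a methoxy group on this same carbon would give a step beyond the scatter. Also open, going by these compounds, is whether a nitrile there would read the same as bromo.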